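Trifluoromethyl for amino: expected cytotoxicity of compound 3

The source may hold more compounds than are shown below. What is called first, only, known or untested is meant among the compounds shown, and "the series" means these compounds.

Compound 1 `Cc1ccc(C(=O)/C=C/c2ccc3c(c2)B(O)OC3)cc1` in a functional assay on SK-OV-3 cells (Homo sapiens) for cytotoxicity, read by MTT assay, with a stated time of 48 h (on this read-out lower numbers stand for stronger inhibition and higher numbers for weaker inhibition), gives 3700 nM. For the measured compounds named here, compound 2 `Nc1ccc(C(=O)/C=C/c2ccc3c(c2)B(O)OC3)cc1` gives 20200 nM in this assay, the highest of the two numbers measured so far. Going by the values given here, the only measured change at this position is a 5.5-fold higher number from compound 1 to compound 2 (0.74 log units; beyond the scatter). Compound 3 `O=C(/C=C/c1ccc2c(c1)B(O)OC2)c1ccc(C(F)(F)F)cc1` differs from compound 2 by trifluoromethyl in place of amino on an aromatic carbon. Among the compounds with values here, no measured step involves trifluoromethyl, but removing the amino group undoes the change that produced a 5.5-fold higher number from compound 1 to compound 2 (0.74 log units; beyond the scatter), so a lower number beyond the scatter is expected, estimated as a 4.5-fold lower number from compound 2 to compound 3 (0.65 log units; beyond the scatter). Compound 3 is therefore expected to give about 4500 nM in this assay, in the range 1500 nM to 14000 nM.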

Compound 3, half-maximal inhibitory concentration: 3700 nM
The estimate for compound 3 lay 1.2-fold (0.09 log units) above the measured number; measured number inside the range.
By their numbers in this assay, from the lowest: compounds 1 and 3 (each within the scatter of the next); then compound 2.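

In this assay, replacing amino with trifluoromethyl reverses the loss seen with amino (a 5.5-fold lower number from compound 2 to compound 3 (0.74 log units; beyond the scatter)). Trifluoromethyl in place of methyl gives no change at the digits printed from compound 1 to compound 3 (within the scatter), so this position tolerates either of these two groups despite their different heavy-atom counts. Among the three groups shown, amino alone stands apart, and it is also the only one of the two groups compared under this change that carries a hydrogen-bond donor. As far as these compounds go, whether a carboxylic acid, a nitrile or a longer chain would track with amino or with methyl and trifluoromethyl remains open. No available evidence explains why amino stands apart.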